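The source may hold more compounds than are shown below. What is called first, only, known or untested is meant among the compounds shown, and "the series" means these compounds.

Compound 1 `CN1C(=S)[C@@H](NC(=O)c2nc(Cc3ccccc3)n(C)n2)COc2ccccc21`: > 100000 nM
Compound 2 `CCCCCn1nc(C(=O)N[C@H]2COc3ccccc3N(C)C2=S)nc1Cc1ccccc1`: > 100000 nM

Both entries come from a toxicity assay on HT-29 cells (Homo sapiens) for cytotoxicity; a lower number here means that less compound is tolerated, a higher number that more compound is tolerated. For compound 1, > 100000 nM is a limit of the assay and not a number. For compound 2, > 100000 nM is likewise a limit, so its standing is known only as a limit. The whole record so far is the limit of > 100000 nM in this assay, at which 2 of the 2 values shown sit.

Compound 3 `CC(C)Cn1nc(C(=O)N[C@H]2COc3ccccc3N(C)C2=S)nc1Cc1ccccc1` differs from compound 2 in one group: isopropyl in place of butyl on a saturated chain carbon bound to an aromatic nitrogen. In words, isopropyl stands in place of butyl on a saturated chain carbon bound to an aromatic nitrogen, and the same difference can be read as pentyl to isobutyl.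

Among the measured compounds shown here, only one measured step bears on this change: a step that the two limits leave unreadable from compound 1 to compound 2. There, butyl took the place of hydrogen on that same carbon, and no size can be read from it. It gives no sign of a change in this assay, so no step beyond the scatter is expected here. The expected result is a number no higher from compound 2 to compound 3 (the limit leaves the size open). Compound 3 is expected to lie near 100000 nM, with an estimated range of 50000 nM to 200000 nM, most likely reported again only as a limit.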

Compound 3, half-maximal cytotoxic concentration: > 100000 nM
Compound 3: no number, only a limit; the forecaster's own chance of this, stated with the estimate: 90%; the middle value sits exactly at the limit.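

The steps among compound 1, compound 2 and compound 3 cannot be read, as all three values in this assay sit at one limit of the assay: the limit of > 100000 nM in this assay, at which 3 of the 3 values shown sit.

The compounds shown leave open whether hydrogen, butyl or isopropyl on that saturated chain carbon makes any difference to the half-maximal cytotoxic concentration.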